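Adding a Sulfamoyl Group to a Dihydroxyphenyl Pyrazole

The compounds below may be only part of what the source reports. "The series", "measured", "known", "first", "only" and "open" are said of these compounds alone.

Of the compounds shown here, three have been measured in a functional assay on cells (Cancer cell lines, Homo sapiens) for cytotoxicity, read by sulforhodamine B assay, with a stated time of 48 h; on this read-out lower numbers stand for stronger inhibition of growth and higher numbers for weaker inhibition of growth. Compound 1 `COc1ccc(OC)c(-c2cc(-c3ccccc3)nn2-c2ccc(S(N)(=O)=O)cc2)c1` gives 15000 nM, compound 2 `Oc1ccc(O)c(-c2cc(-c3ccccc3)nn2-c2ccccc2)c1` gives 18600 nM, and compound 3 `Oc1ccc(O)c(-c2cc(-c3ccc(Cl)cc3)nn2-c2ccccc2)c1` gives 17900 nM. Compound 2 stands within the scatter of both others; compound 3 lies nearest and compound 1 furthest, yet even that gap is within the scatter. Compound 4 `NS(=O)(=O)c1ccc(-n2nc(-c3ccccc3)cc2-c2cc(O)ccc2O)cc1` has not been measured; it differs from compound 2 by sulfamoyl in place of hydrogen on an aromatic carbon. Among the measured compounds shown here, no measured step makes this exact change. For the measured compounds named here, the only measured step, a 1.0-fold lower number from compound 2 to compound 3 (0.02 log units; within the scatter), adds a different group and stays within the scatter, and compound 1, which carries the same sulfamoyl group on an otherwise altered core, sits close to compound 2. The step of a 1.2-fold lower number from compound 2 to compound 4 (0.07 log units; within the scatter) is therefore expected to stay within the scatter. Compound 4 is estimated at 16000 nM, between 7000 nM and 36000 nM.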

Compound 4, concentration for 50% growth inhibition: 86600 nM
For compound 4 the middle estimate is 5.4-fold (0.73 log units) below the measured one, and the stated range ends below it.
By their numbers in this assay, from the lowest: compounds 1, 3 and 2 (each within the scatter of the next); then compound 4.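

Sulfamoyl on this aromatic carbon, para to a large group, is not neutral when the other ring is 2,5-dihydroxyphenyl: in this assay growth inhibition weakens (a 4.7-fold higher number from compound 2 to compound 4 (0.67 log units; beyond the scatter)). With sulfamoyl held in place, the swap of 2,5-dimethoxyphenyl for 2,5-dihydroxyphenyl also weakens it (a 5.8-fold higher number from compound 1 to compound 4 (0.76 log units; beyond the scatter)), so the outcome depends on that second group too. Nothing available explains either loss. Open, on these data alone, is whether sulfamoyl has any such effect alongside 2,5-dimethoxyphenyl, and whether an amine or a carboxylic acid at this position would behave the same way.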